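This account rests on a few compounds, and the source may have more. Where it says the series, first, only, none or still open, it means among the compounds named here.

Measured compounds:
compound 1, `CC(C)(C)OC(=O)N1CCCN(CCCCCOc2c(Br)cc(Br)cc2Oc2ccc(Br)cc2Br)CC1`, 44.8 ug/mL
compound 2, `COc1c(Br)cc(Br)cc1Oc1ccc(Br)cc1Br`, 28.2 ug/mL

Both values come from a functional assay on HL-60 cells (Homo sapiens) for cytotoxicity, read by MTT assay, with a stated time of 24 h; on this read-out lower numbers stand for stronger inhibition and higher numbers for weaker inhibition. Among the compounds with values here, compound 2 gives 28.2 ug/mL in this assay; the only other measured compound, compound 1, sits within the usual scatter of that number, so the two cannot be told apart on this read-out.

Compound 3, `BrCCOc1c(Br)cc(Br)cc1Oc1ccc(Br)cc1Br`, has not yet been measured in this assay. It differs from compound 2 in one place: bromomethyl in place of hydrogen on a saturated chain carbon bound to an oxygen on an aromatic ring. Within the data shown here, with no measured step between compounds that differ in just one place, there is nothing here to show how a change of this kind moves the read-out. The expectation is therefore that the step of a 1.1-fold lower number from compound 2 to compound 3 (0.05 log units; within the scatter) stays within the scatter, with no clear direction. On that basis compound 3 is estimated at 25 ug/mL in this assay, with a range from 10 ug/mL to 60 ug/mL.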

Compound 3, half-maximal inhibitory concentration: 26.2 ug/mL
Beside the measured number, compound 3's estimate is 1.0-fold (0.02 log units) below it; measured number inside the range.
By their numbers in this assay, from the lowest: compounds 3, 2 and 1 (each within the scatter of the next).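

Within the data shown here, the step from methoxy to 2-bromoethoxy is the first one-place comparison available in this assay, and it reads a 1.1-fold lower number from compound 2 to compound 3 (0.03 log units; within the scatter), within the scatter. On this read-out, then, compound 2 and compound 3 cannot be told apart, so bromomethyl in place of hydrogen on a saturated chain carbon bound to an oxygen on an aromatic ring leaves no detectable mark. Nothing available accounts for this result.

This single step rests on one substituent in one cell assay, so it does not show how far the position tolerates other changes. On these data alone, whether a hydroxyl, an amine or a carboxylic acid in place of the bromine at the end of the 2-bromoethoxy chain would shift the number remains open.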